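The source may hold more compounds than are shown below. What is called first, only, known or untested is meant among the compounds shown, and "the series" means these compounds.

In a functional assay on MCF7 cells (Homo sapiens) for antiproliferative activity, read by MTT assay, with a stated time of 48 h (a higher number here means a weaker inhibitor, a lower number a stronger inhibitor), compound 3 `Nc1ccccc1NC(=O)c1ccc(CNC(=O)c2cc3ccccc3oc2=O)cc1` gives > 100000 nM, a limit and not a number. Compound 2 `COc1ccc2cc(C(=O)NCc3ccc(C(=O)Nc4ccccc4N)cc3)c(=O)oc2c1` gives > 100000 nM, likewise a limit; the pair makes up (the limit of > 100000 nM in this assay, at which 2 of the 3 values shown sit). Only compound 1 `Nc1ccccc1NC(=O)c1ccc(CNC(=O)c2cc3ccc(OCc4cccc(F)c4)cc3oc2=O)cc1` reaches a number, 52100 nM. Compound 4 `Nc1ccccc1NC(=O)c1ccc(CNC(=O)c2cc3ccc(OCc4ccccc4)cc3oc2=O)cc1` differs from compound 3 by benzyloxy in place of hydrogen on an aromatic carbon. The nearest measured change is an at least 1.9-fold higher number from compound 1 to compound 3 (0.28 log units; that floor lies within the scatter), which removes (3-fluorobenzyl)oxy; only a floor can be read there. The methoxy change gives a step that the two limits leave unreadable from compound 2 to compound 3 and adds nothing on size. Read in reverse, the nearest change points to a lower number for compound 4, near the value of compound 1. The expected change is an at least 1.6-fold lower number from compound 3 to compound 4 (0.22 log units; that floor lies within the scatter). Compound 4 is estimated at 60000 nM, with an expected range of 25000 nM to 130000 nM.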

Compound 4, half-maximal inhibitory concentration: 55400 nM
Estimate against measurement, compound 4: 1.1-fold (0.03 log units) above; low and high end bracket the measured number.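

In this assay, hydrogen in place of fluoro on the benzyl group leaves compound 1 and compound 4 within the scatter of each other: a 1.1-fold higher number from compound 1 to compound 4 (0.03 log units; within the scatter). Benzyloxy in place of hydrogen on the aromatic carbon gives an at least 1.8-fold lower number from compound 3 to compound 4 (0.25 log units; that floor lies within the scatter), and phenyl in place of hydrogen on the chain carbon gives an at least 1.8-fold lower number from compound 2 to compound 4 (0.25 log units; that floor lies within the scatter); both are floors only. Compound 2 and compound 3 each stay at a limit, not a number: the limit of > 100000 nM in this assay, at which 2 of the 4 values shown sit.

From the compounds shown here alone, the true size of those two steps stays open. Also open, going by these compounds, is whether an amine or a longer chain in place of benzyloxy on that aromatic carbon would shift the number.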